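Amide aryl swap on a shared core: working notes

A few compounds are considered here, and "the series" means these few. Any claim that something is new, unique, unknown or untested is made for them only; others in the source may bear on it.

compound 1 `Cc1cnc(NC(=O)COc2ccc(/C=C3\SC(=O)NC3=O)cc2)s1` — < 100000 nM
compound 2 `CCCCC1=NC2(CCCC2)C(=O)N1C(=O)COc1ccc(/C=C2/SC(=O)NC2=O)cc1` — < 100000 nM

Compound 1 is known in a functional assay on HepG2 cells (Homo sapiens) for cytotoxicity, read by sulforhodamine B assay, with a stated time of 48 h (on this read-out higher numbers stand for weaker inhibition of growth and lower numbers for stronger inhibition of growth), only as a limit. In this assay compound 1 gives < 100000 nM, which is a limit and not a number. Compound 2 likewise reaches only a limit in this assay, < 100000 nM. Going by the values given here, both readings sit at the limit of < 100000 nM in this assay, at which 2 of the 2 values shown sit, so no measured step exists and compound 1 cannot be placed by a number. Compound 3 `O=C(COc1ccc(/C=C2\SC(=O)NC2=O)cc1)Nc1ccccn1` carries pyridin-2-yl in place of 5-methyl-1,3-thiazol-2-yl on an amide-type nitrogen. Among the compounds with values here, with no measured step to lean on, the change from compound 1 to compound 3 is expected to stay within the scatter, as a step that the limit leaves unreadable from compound 1 to compound 3. Compound 3 is thus estimated at 50000 nM, within 5000 nM to 100000 nM, and another limit is likely.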

Compound 3, concentration for total growth inhibition: < 100000 nM
Compound 3: no number, only a limit; the forecaster's own chance of this, stated with the estimate: 70%; the middle value does not contradict the limit.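

Compound 3 also gives only a limit in this assay, so the swap from compound 1 to compound 3 yields no readable step: the limit of < 100000 nM in this assay, at which 3 of the 3 values shown sit. As far as these compounds go, how far compound 1, compound 2 and compound 3 actually differ in growth inhibition remains open.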